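The source may hold more compounds than are shown below. What is called first, only, known or untested is meant among the compounds shown, and "the series" means these compounds.

Measured compounds:
compound 1 `CC1(C)CC(NC(=O)c2ccc(Nc3ncc([N+](=O)[O-])c(NC4CCCC4)n3)cc2)CC(C)(C)N1[O]`: 33200 nM
compound 2 `CCN1CCN(c2nc(Nc3ccc(C(=O)NC4CC(C)(C)N([O])C(C)(C)C4)cc3)ncc2[N+](=O)[O-])CC1`: 1960 nM

In a functional assay on A549 cells (Homo sapiens) for antiproliferative activity, read by MTT assay, with a stated time of 48 h (on this read-out higher numbers stand for weaker inhibition and lower numbers for stronger inhibition), compound 2 gives 1960 nM, the lowest of the two numbers. Among the measured compounds shown here, compound 1, the only other measured compound, gives 33200 nM. For the measured compounds named here, the one measured step, a 17-fold lower number from compound 1 to compound 2 (1.23 log units; beyond the scatter), is large and beyond the scatter. Compound 3 `Cc1cc(Nc2nc(Nc3ccc(C(=O)NC4CC(C)(C)N([O])C(C)(C)C4)cc3)ncc2[N+](=O)[O-])no1` is the next compound. The change from compound 2 is (5-methyl-1,2-oxazol-3-yl)amino in place of 4-ethylpiperazin-1-yl on an aromatic carbon. Going by the values given here, no measured step covers this exchange: the measured step swaps a cyclopentylamino for a 4-ethylpiperazin-1-yl, whereas the new step removes that same 4-ethylpiperazin-1-yl and puts in an amino-linked aromatic group. Since compound 1, which also carries an amino-linked group at this carbon, gives 33200 nM, compound 3 is expected to move back toward a higher number, by about a 3.1-fold higher number from compound 2 to compound 3 (0.49 log units; beyond the scatter). The estimate for compound 3 is 6000 nM, with a range from 1500 nM to 25000 nM.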

Compound 3, half-maximal inhibitory concentration: 1140 nM
Estimate against measurement, compound 3: 5.3-fold (0.72 log units) above; the measured number lies below the stated range.
By their numbers in this assay, from the lowest: compounds 3 and 2 (each within the scatter of the next); then compound 1.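

In this assay the step from a saturated ring to an amino-linked aromatic ring at this carbon gives a 1.7-fold lower number from compound 2 to compound 3 (0.24 log units; within the scatter) and so does not separate the two groups, although they differ in ring type and hydrogen-bond donors. With the nitrogen link kept and cyclopentyl replaced by 5-methyl-1,2-oxazol-3-yl, the result is a 29-fold lower number from compound 1 to compound 3 (1.46 log units; beyond the scatter) and the amino link alone therefore does not go with the high number of compound 1, since what the nitrogen carries makes the difference among these compounds. Nothing measured here explains either step.

The compounds shown leave open whether the methyl on the oxazole ring matters, and how a phenylamino group on the same carbon would compare. They also leave open whether a nitrile could stand in place of the nitro group.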